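The source may report more compounds than this note shows. Statements on the series, on what has been measured and on what is new or still open speak of the compounds shown alone.

Compounds measured in a functional assay on L1210 cells (Mus musculus) for inhibition, read by cell counting, with a stated time of 2 days; a higher number here means a weaker inhibitor, a lower number a stronger inhibitor:
- compound 2, `C=C(Br)C(=O)Nc1cccc(-c2cn3nc(-c4ccccc4)sc3n2)c1`: 600 nM
- compound 3, `C=C(Br)C(=O)Nc1cccc(-c2cn3nc(-c4ccc(C)cc4)sc3n2)c1`: 920 nM
- compound 1, `Nc1cccc(-c2cn3nc(-c4cccs4)sc3n2)c1`: > 250000 nM, which is a limit of the assay and not a number

Compound 3 holds the highest of the two numbers; its nearest neighbour is compound 2, and the step of a 1.5-fold higher number from compound 2 to compound 3 (0.19 log units; within the scatter) places the two within the scatter. Compound 1 carries the thiophen-2-yl group on the shared core but lacks the bromoacrylamide, and in this assay it reaches only a limit, (the limit of > 250000 nM in this assay, at which 1 of the 3 values shown sits).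

Compound 4, `C=C(Br)C(=O)Nc1cccc(-c2cn3nc(-c4cccs4)sc3n2)c1`, is the next compound. Its change from compound 3 is thiophen-2-yl in place of 4-methylphenyl on an aromatic carbon. Among the compounds with values here, no measured step bears on it directly; the only step at the same place, a 1.5-fold higher number from compound 2 to compound 3 (0.19 log units; within the scatter), was within the scatter, which suggests that this position tolerates exchange without a large shift. Compound 1 and compound 4 share the thiophen-2-yl group but differ in the acrylamide, so the limit of compound 1 gives no guide to the size of this step.

Compound 4 is therefore expected to show no step beyond the scatter, a 1.3-fold lower number from compound 3 to compound 4 (0.12 log units; within the scatter). Compound 4 is estimated at 700 nM, with a range from 250 nM to 2500 nM.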

Compound 4, half-maximal inhibitory concentration: 170 nM
Compound 4: middle estimate off by 4.1-fold (0.61 log units), on the high side, and the stated range ends above it.
By their numbers in this assay, from the lowest: compound 4; then compounds 2 and 3 (each within the scatter of the next). At a limit, above all of these: compound 1.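

In this assay, the position that looked tolerant from a 1.5-fold higher number from compound 2 to compound 3 (0.19 log units; within the scatter) now separates its groups, since thiophen-2-yl in place of 4-methylphenyl gives a 5.4-fold lower number from compound 3 to compound 4 (0.73 log units; beyond the scatter) and thiophen-2-yl in place of phenyl gives a 3.5-fold lower number from compound 2 to compound 4 (0.55 log units; beyond the scatter). With thiophen-2-yl held fixed, placing the (1-bromoethenyl)carbonyl group on the nitrogen gives an at least 1400-fold lower number from compound 1 to compound 4 (3.16 log units; beyond the scatter), a step that starts from a limit of the assay and not a number: the limit of > 250000 nM in this assay, at which 1 of the 4 values shown sits. Nothing shown here accounts for the gain seen with thiophen-2-yl.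

As far as these compounds go, how a furan-2-yl ring or an amine at this position would compare remains open. So does whether a plain acetyl group on that nitrogen would keep any part of the large step.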